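A few compounds are considered here, and "the series" means these few. Any claim that something is new, unique, unknown or untested is made for them only; others in the source may bear on it.

Compound 1 `CC(C)=CCOc1ccc(C(=O)/C=C/c2ccncc2)c(O)c1` and compound 2 `CC(C)=CCOc1ccc(C(=O)/C=C/c2cccnc2)c(O)c1` share one core and differ by a single change, (pyridin-3-yl in place of pyridin-4-yl on a double-bonded chain carbon bound to a double-bonded chain carbon). In an ADME assay on THP-1 cells (Homo sapiens) for cytotoxicity, read by resazurin assay, with a stated time of 72 h (on this read-out lower numbers stand for higher toxicity in this test and higher numbers for lower toxicity in this test), compound 1 gives 16000 nM, while compound 2 gives 100000 nM, so the change produced a 6.3-fold higher number from compound 1 to compound 2 (0.80 log units; beyond the scatter). Compound 3 `C#CCOc1ccc(C(=O)/C=C/c2ccncc2)c(OCC#C)c1` rests on a different core; how that core differs from the core of compound 1 is not broken down here. In this assay compound 3 gives 11000 nM, which sits within the scatter of compound 1. Compound 4 `C#CCOc1ccc(C(=O)/C=C/c2cccnc2)c(OCC#C)c1` is related to compound 3 by pyridin-3-yl in place of pyridin-4-yl on a double-bonded chain carbon bound to a double-bonded chain carbon, the same change that separates compound 1 from compound 2, made at the same place. Compound 4 has not yet been measured in this assay. Because the earlier step of a 6.3-fold higher number from compound 1 to compound 2 (0.80 log units; beyond the scatter) lies beyond the scatter, compound 4 is expected to move by a step of comparable size, estimated as a 5.0-fold higher number from compound 3 to compound 4 (0.70 log units; beyond the scatter), though the other core leaves room for a smaller shift. On that basis compound 4 is estimated at 55000 nM, expected to fall between 22000 nM and 140000 nM.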

Compound 4, half-maximal cytotoxic concentration: 15000 nM
Estimate against measurement, compound 4: 3.7-fold (0.56 log units) above; the measured number lies below the stated range.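

In this assay the exchange of pyridin-4-yl for pyridin-3-yl gives a 1.4-fold higher number from compound 3 to compound 4 (0.13 log units; within the scatter) and so does not separate the two compounds on the core of compound 3, whereas the same exchange did separate compound 1 from compound 2. The change therefore did not carry its size from one core to the other: the same change on two cores in this assay, a 6.3-fold higher number (0.80 log units; beyond the scatter) from compound 1 to compound 2 and a 1.4-fold higher number (0.13 log units; within the scatter) from compound 3 to compound 4, 4.6-fold (0.66 log units) apart, beyond the scatter of two such steps. This shows that, across these two pairs, the size of the step depends on the core, but it does not show which feature of the two cores is responsible or what the step would be on any third core.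

The compounds shown leave open how far the step would follow the groups on the core if a methoxy group or a longer alkyl chain were attached through the same oxygens. They also leave open how pyridin-2-yl or a plain phenyl ring would behave on a double-bonded chain carbon bound to a double-bonded chain carbon, on either core.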